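From benzyloxy to chloro in a growth inhibition test

The source may hold more compounds than are shown below. What is called first, only, known or untested is meant among the compounds shown, and "the series" means these compounds.

In an ADME assay on NIH3T3 cells (Mus musculus) for cytotoxicity, read by MTT assay, with a stated time of 24 h (a higher number here means a weaker inhibitor of growth, a lower number a stronger inhibitor of growth), compound 1 (`c1ccc(COc2ccc(C3CC(c4ccc5c(c4)OCCO5)=NN3c3ccccc3)cc2)cc1`) gives 229000 nM and compound 2 (`c1ccc(COc2cccc(C3CC(c4ccc5c(c4)OCCO5)=NN3c3ccccc3)c2)cc1`) gives 222000 nM as its reading. Compound 2 therefore stands level with compound 1, since their two numbers lie within the usual scatter of each other.

The next molecule, compound 3 (`Clc1cccc(C2CC(c3ccc4c(c3)OCCO4)=NN2c2ccccc2)c1`), is made from compound 2 by one change: chloro in place of benzyloxy on an aromatic carbon. Among the measured compounds shown here, no measured pair of compounds yet shows what a swap of this kind does, so the data give no direction for it. For that reason, no step beyond the scatter is expected in this assay for this change. The estimated step (a 1.1-fold lower number from compound 2 to compound 3 (0.05 log units; within the scatter)) is accordingly a small one. The estimate for compound 3 is an expected value of 200000 nM (range 80000 nM to 400000 nM).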

Compound 3, concentration for 50% growth inhibition: 172000 nM
Compound 3: the middle estimate sits 1.2-fold (0.07 log units) above what was measured, within the range that was stated.
By their numbers in this assay, from the lowest: compounds 3, 2 and 1 (each within the scatter of the next).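

In this assay, among the compounds shown here, the swap of benzyloxy for chloro on this aromatic carbon amounts to a 1.3-fold lower number from compound 2 to compound 3 (0.11 log units; within the scatter), the first measured step for this change. A group of 8 heavy atoms with an aromatic ring and a hydrogen-bond acceptor gives way to a single chlorine atom, yet the two readings remain within the scatter of each other, so in this one pair the whole benzyloxy group can go without a clear step in this assay. No measurement at hand explains this result.

On these data alone, whether a different group at this place, such as an amine or a carboxylic acid, would move the reading beyond the scatter remains open. It is also unsettled whether chloro would give a similar reading at the place benzyloxy holds in compound 1.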